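A few compounds are considered here, and "the series" means these few. Any claim that something is new, unique, unknown or untested is made for them only; others in the source may bear on it.

Measured compounds: compound 1, `C=C1C(=O)O[C@H](c2ccc3ccccc3c2)[C@H]1C`, with 139% in a functional assay on PANC-1 cells (Homo sapiens) for cytotoxicity, read by MTT assay, with a stated time of 72 h, tested at 1 uM; on this read-out lower numbers stand for a stronger effect and higher numbers for a weaker effect at the one concentration tested; compound 2, `C=C1C(=O)O[C@@H](c2ccc3ccccc3c2)[C@H]1c1ccccc1`, with 98% in this assay.

Compound 2 gives the lowest of the two numbers shown in this assay; its nearest neighbour, compound 1, lies higher by a gap beyond the usual scatter. The unmeasured compound 3, `C=C1C(=O)O[C@H](c2ccc3ccccc3c2)[C@H]1c1ccccc1`, differs from compound 2 as follows: the two compounds have the same atoms and bonds and differ only in configuration as drawn: 1 of 2 stereo elements differ; a stereocentre at a saturated ring carbon is drawn R in compound 2 and S in compound 3. Going by the values given here, no measured pair shows the effect of such a change in configuration, so only a modest step is expected from compound 2 to compound 3 in this assay, with the direction uncertain and possibly no change beyond the scatter. Compound 3 is therefore estimated at 100%, between 70% and 135%, an expected step of a number 2 percentage points higher from compound 2 to compound 3 (within the scatter).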

Compound 3, a percentage reported as activity, at one concentration (the size of the read-out at that concentration, not a potency): 53%
Estimate against measurement, compound 3: 47 percentage points above; the whole stated range lies above it.
By their numbers in this assay, from the lowest: compound 3; then compound 2; then compound 1.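

Configuration at this saturated ring carbon matters on its own in this assay (a number 45 percentage points lower from compound 2 to compound 3 (beyond the scatter)). That large step can be assigned to the configuration because of how the pair is related: the fact that compounds 2 and 3 differ only in the configuration as drawn. Phenyl in place of methyl on a saturated ring carbon also comes with a large step (a number 86 percentage points lower from compound 1 to compound 3 (beyond the scatter)), which can be read only for the configuration drawn in compound 3.

As far as these compounds go, whether an ethyl chain or an amine at this position would behave more like methyl or like phenyl stays open. So does how compound 3 behaves at other concentrations.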